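Epoxide in Place of Isobutyl on a Flavanone Core

The source may report more compounds than this note shows. Statements on the series, on what has been measured and on what is new or still open speak of the compounds shown alone.

Compound 1 `C#CCOc1ccc([C@@H]2CC(=O)c3cc(CC=C(C)C)c(OC)cc3O2)cc1`: 75%
Compound 2 `COc1cc2c(cc1CCC(C)C)C(=O)C[C@@H](c1ccc(O)cc1)O2`: 77%

In a functional assay on HCT-116 cells (Homo sapiens) for inhibition, read by sulforhodamine B assay, with a stated time of 48 h, tested at 50 uM (a lower number here means less inhibition of growth, a higher number more inhibition of growth at the concentration tested), compound 2 gives 77%, while compound 1 gives 75%; the two values lie within the scatter of each other, so neither can be said to differ from the other. Compound 3 `COc1cc2c(cc1CC1OC1(C)C)C(=O)C[C@@H](c1ccc(O)cc1)O2` is not yet measured. It differs from compound 2 in one place: 3,3-dimethyloxiran-2-yl in place of isobutyl on a saturated chain carbon bound to an aromatic carbon. For the measured compounds named here, no measured pair shows the effect of such a change here. The step in this assay from compound 2 to compound 3 is expected to be small, a number 5 percentage points lower from compound 2 to compound 3 (within the scatter), with no clear direction beyond the scatter. Compound 3 is therefore estimated at 72%, between 50% and 88%.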

Compound 3, percent growth inhibition at one concentration: 97%
The estimate for compound 3 lay 25 percentage points below the measured number, outside the stated range (above it).
By their numbers in this assay, from the lowest: compounds 1 and 2 (each within the scatter of the next); then compound 3.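

In this assay putting 3,3-dimethyloxiran-2-yl in place of isobutyl on a saturated chain carbon bound to an aromatic carbon gives a number 20 percentage points higher from compound 2 to compound 3 (beyond the scatter) and so shows that growth inhibition responds to the group at this place. The entering group brings a three-membered ring with an oxygen, but this single pair cannot separate the ring from the oxygen. Nothing available explains the rise. Still open, as far as these compounds go, is whether an open-chain diol or an amine at this place would give a similar number, and whether a simple ether would do the same.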